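The compounds below may be only part of what the source reports. "The series", "measured", "known", "first", "only" and "open" are said of these compounds alone.

In a functional assay on A-375 cells (Homo sapiens) for antiproliferative activity, read by MTT assay, with a stated time of 24 h, tested at 0.14 ug/mL (on this read-out higher numbers stand for a stronger effect at the one concentration tested and lower numbers for a weaker effect), compound 1, `Cc1c(C(=O)Nc2c(F)cc(-c3cccc(F)c3)cc2F)nc2ccc(F)cc2c1O`, gives 0%. Compound 2, `Cc1c(C(=O)Nc2c(F)cc(-c3cccc(F)c3)cc2F)nc2ccc(F)cc2c1C(=O)O`, differs from it by a carboxy in place of a hydroxy on an aromatic carbon, and in this assay compound 2 gives 1.05%. The step of a number 1.1 percentage points higher from compound 1 to compound 2 (within the scatter) leaves the two numbers indistinguishable, so compound 2 stands at one of two values that lie within the usual scatter of each other, both near the bottom of the scale.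

Compound 3, `Cc1c(C(=O)Nc2c(F)cc(-c3cccc(F)c3)cc2F)nc2ccc(C(F)(F)F)cc2c1C(=O)O`, is the next compound, and it differs from compound 2 as follows: trifluoromethyl in place of fluoro on an aromatic carbon

Going by the values given here, no measured step concerns this kind of change. Among the compounds with values here, the only step known, a number 1.1 percentage points higher from compound 1 to compound 2 (within the scatter), touched a different group and stayed within the scatter, and neither compound 1 nor compound 2 showed any appreciable effect in this assay. There is therefore no ground for expecting a step in this assay beyond the scatter in either direction. For compound 3 the expected step is a number 1 percentage points higher from compound 2 to compound 3 (within the scatter). The estimate for compound 3 in this assay is 2%, with a range from 0% to 12%.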

Compound 3, a percentage reported as inhibition, at one concentration (the size of the read-out at that concentration, not a potency): 2.56%
For compound 3 the middle estimate is 0.6 percentage points below the measured one, and the stated range covers the measured number.
By their numbers in this assay, from the lowest: compounds 1, 2 and 3 (each within the scatter of the next).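

In this assay, trifluoromethyl in place of fluoro on this aromatic carbon, meta to a fused ring and para to a fused ring, gives a number 1.5 percentage points higher from compound 2 to compound 3 (within the scatter). Going by these compounds alone, this is the first look at this position, as the earlier pair differed at another place, and it shows that four heavy atoms can stand here in place of one without the read-out leaving the scatter, with compound 2 at 1.05% and compound 3 at 2.56%, both close to the bottom of the scale at the one concentration tested. Nothing at hand accounts for this result or bears on what either group does here.

Since all three compounds lie within the scatter of one another close to the bottom of the scale, a single concentration cannot tell whether this position has any influence on the antiproliferative read-out or whether the shared core simply gives too little effect for a difference to appear. As far as these compounds go, it also remains open whether an amine, a methoxy group or a longer alkyl chain on this aromatic carbon would give a step beyond the scatter.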